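Iodine on the core: expected cytotoxicity of compound 4

The source may hold more compounds than are shown below. What is called first, only, known or untested is meant among the compounds shown, and "the series" means these compounds.

Measured compounds:
compound 1 `O=c1ccn(COC(CO)CO)c(=O)[nH]1` gives in a functional assay on Vero cells (Chlorocebus sabaeus) for cytotoxicity; on this read-out lower numbers stand for higher toxicity in this test and higher numbers for lower toxicity in this test > 462000 nM, a limit of this assay
compound 2 `Nc1ccn(COC(CO)CO)c(=O)n1` gives in this assay > 465000 nM, a limit of this assay
compound 3 `Cc1cc(=O)[nH]c(=O)n1COC(CO)CO` gives in this assay > 434000 nM, a limit of this assay

Among the compounds with values here, compound 3 sits at a limit of this assay rather than at a number, and the two other values shown are limits too, so no compound here stands apart from the others. Within the data shown here, the single step between measured compounds, a step that the two limits leave unreadable from compound 1 to compound 3, is left unreadable by the two limits; the lines (the limit of > 434000 nM in this assay, at which 1 of the 3 values shown sits), the limit of > 462000 nM in this assay, at which 1 of the 3 values shown sits, and the limit of > 465000 nM in this assay, at which 1 of the 3 values shown sits, record only where those limits lie.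

Compound 4 `Cc1c(I)c(=O)[nH]c(=O)n1COC(CO)CO` differs from compound 3 by iodo in place of hydrogen on an aromatic carbon. Among the measured compounds shown here, the one measured step that touches this part of the core, a step that the two limits leave unreadable from compound 1 to compound 3, gives no readable size, so there is no measured basis for a step in either direction beyond the scatter in this assay. Compound 4 is therefore expected to show, relative to compound 3, a step of about an at least 1.0-fold lower number from compound 3 to compound 4 (0.03 log units; that floor lies within the scatter). Compound 4 is estimated to give about 400000 nM in this assay, within a range from 100000 nM to 500000 nM, most likely again reported as a limit.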

Compound 4, half-maximal cytotoxic concentration: > 280000 nM
Compound 4: no number, only a limit; the forecaster's own chance of this, stated with the estimate: 75%; the middle value lies beyond the limit too.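

In this assay compound 4 gives > 280000 nM, a limit of the assay. Compound 3 also stands at a limit, so no step can be read from compound 3 to compound 4: the limit of > 280000 nM in this assay, at which 1 of the 4 values shown sits. The compounds shown leave open whether iodo in place of hydrogen on an aromatic carbon shifts the read-out at all, since none of them gives a number.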